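Indole Nitrogen Methylation in a Weakly Cytotoxic Hydrazone Pair

The compounds below may be only part of what the source reports. "The series", "measured", "known", "first", "only" and "open" are said of these compounds alone.

Compound 2 `COc1ccc(Cn2cc(/C=N\NC(=O)c3c[nH]c4ccccc34)c3ccc(F)cc32)cc1` stands at the lower of two numbers in a functional assay on MDA-MB-231 cells (Homo sapiens) for cytotoxicity (on this read-out lower numbers stand for stronger inhibition and higher numbers for weaker inhibition), giving 71200 nM; its neighbour compound 1 `COc1ccc(Cn2cc(/C=N\NC(=O)c3c[nH]c4ccc(Br)cc34)c3ccc(F)cc32)cc1` gives 99800 nM, and the step of a 1.4-fold lower number from compound 1 to compound 2 (0.15 log units; within the scatter) lies within the scatter. Among the compounds with values here, compound 3 `COc1ccc(Cn2cc(/C=N\NC(=O)c3cn(C)c4ccccc34)c3ccc(F)cc32)cc1` carries the change (methyl in place of hydrogen on an aromatic nitrogen), an exchange on an aromatic nitrogen that no measured step addresses directly. Within the data shown here, the one measured step, a change on an aromatic carbon, stayed within the scatter, so no step beyond the scatter is expected for this assay either. Compound 3 is therefore estimated at 75000 nM, in the range 30000 nM to 200000 nM, corresponding to the expected step of a 1.1-fold higher number from compound 2 to compound 3 (0.02 log units; within the scatter).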

Compound 3, half-maximal inhibitory concentration: 17700 nM
Estimate against measurement, compound 3: 4.2-fold (0.63 log units) above; the measured number lies below the stated range.
By their numbers in this assay, from the lowest: compound 3; then compounds 2 and 1 (each within the scatter of the next).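

In this assay, within the data shown here, methyl in place of hydrogen on the aromatic nitrogen gives a 4.0-fold lower number from compound 2 to compound 3 (0.60 log units; beyond the scatter) and is the first single change here to lie beyond the scatter, which the exchange of bromo for hydrogen on an aromatic carbon did not do. The 1-methyl-1H-indol-3-yl group in place of 5-bromo-1H-indol-3-yl gives a 5.6-fold lower number from compound 1 to compound 3 (0.75 log units; beyond the scatter) in the same direction. Nothing available here accounts for this shift. Still open, from the compounds shown here alone, is whether an ethyl group or a longer chain on this nitrogen would lower the number further, and whether methyl would do the same with bromo kept on the core.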